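This account rests on a few compounds, and the source may have more. Where it says the series, first, only, none or still open, it means among the compounds named here.

Compound 1, with the structure `CCN(Cc1cccc(Cl)c1)C(=O)C1CCN(S(=O)(=O)c2ccc3cn[nH]c3c2)CC1`, reaches 77% in a functional assay on CHO cells for positive allosteric modulation of muscarinic acetylcholine receptor M5 (Homo sapiens), read by calcium flux; on this read-out lower numbers stand for smaller maximal responses and higher numbers for larger maximal responses. Compound 2, with the structure `C=CCN(Cc1ccccc1C(F)(F)F)C(=O)C1CCN(S(=O)(=O)c2ccc3[nH]ncc3c2)CC1`, gives 79% in this assay. Among the measured compounds shown here, of the two numbers measured so far, that of compound 2 is the higher one, but the only other value, that of compound 1, lies so close to it that the gap falls within the usual scatter of repeated measurements, so the two compounds cannot be told apart on this read-out.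

Compound 3, with the structure `CC(C)(C)CN(Cc1ccccc1C(F)(F)F)C(=O)C1CCN(S(=O)(=O)c2ccc3[nH]ncc3c2)CC1`, differs from compound 2 in one place: tert-butyl in place of vinyl on a saturated chain carbon bound to an amide-type nitrogen. For the measured compounds named here, no pair of measured compounds shows what such a change on this position does, so there is no measured step to lean on. With both measured compounds resting in the same region, the change is expected to leave the maximal response roughly where compound 2 stands, with no step beyond the scatter in either direction.

Compound 3 is therefore expected to reach about 75% in this assay, within a range from 60% to 90%, which means an expected step of a number 4 percentage points lower from compound 2 to compound 3 (within the scatter).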

Compound 3, largest response reached (reported as percent of maximum), in percent of the reference or control that the assay uses: 104%
Beside the measured number, compound 3's estimate is 29 percentage points below it, outside the stated range (above it).
By their numbers in this assay, from the lowest: compounds 1 and 2 (each within the scatter of the next); then compound 3.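

Among the compounds shown here, the group on the saturated chain carbon bound to an amide-type nitrogen proves able to move the maximal response, which the two earlier compounds could not show, as they offered no step at this place. In this assay, tert-butyl in place of vinyl, which can also be read as neopentyl in place of allyl, gives a number 25 percentage points higher from compound 2 to compound 3 (beyond the scatter). This single change takes 2 heavy atoms and a double bond out and puts 4 heavy atoms and no double bond in, and nothing measured here explains why the response follows it.

The one step changes chain size and saturation together, so the compounds shown leave open which of the two goes with the larger response, and a saturated propyl or isobutyl group on the same carbon would separate them. Also open, as far as these compounds go, is whether the response keeps rising with a still longer chain or a ring such as cyclohexyl at this place, or whether a polar group such as an amine or a carboxylic acid would be accepted there.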